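Swapping Phenyl for Pyridin-3-yl on a Potent Analogue

The source may hold more compounds than are shown below. What is called first, only, known or untested is meant among the compounds shown, and "the series" means these compounds.

Of the compounds shown here, two sharing one core have been measured in a functional assay on cells for inhibition of growth hormone secretagogue receptor type 1 (Homo sapiens), read by FLIPR and calcium flux; on this read-out higher numbers stand for an effect only at larger amounts of compound and lower numbers for an effect already at smaller amounts. Compound 1 `CC(C)(N)C(=O)N[C@H](COCc1ccc(OC(F)(F)F)cc1)c1nnnn1CCOC(=O)NCCCCO` gives 33.2 nM in this assay. Within the data shown here, compound 2 `CC(C)(N)C(=O)N[C@H](COCc1ccccc1-c1ccccc1)c1nnnn1CCOC(=O)NCCCCO` gives 0.34 nM in this assay, the lowest of the two numbers, with compound 1 as its only neighbour. The two differ in a single aromatic group: compound 1 carries 4-(trifluoromethoxy)phenyl where compound 2 carries 2-phenylphenyl. The step of a 98-fold lower number from compound 1 to compound 2 (1.99 log units; beyond the scatter) is large.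

Compound 3 `CC(C)(N)C(=O)N[C@H](COCc1ccccc1-c1cccnc1)c1nnnn1CCOC(=O)NCCCCO` keeps everything of compound 2 except one change: pyridin-3-yl in place of phenyl on an aromatic carbon. Among the measured compounds shown here, no measured step bears directly on this change, since the only step seen exchanged the entire aromatic group, whereas here the outer phenyl alone becomes pyridin-3-yl while the inner ring stays. Without a comparable step, the expected change in this assay is small, and the step expected is a 2.9-fold higher number from compound 2 to compound 3 (0.47 log units; beyond the scatter). Compound 3 is therefore estimated at 1 nM, with a range from 0.3 nM to 4 nM.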

Compound 3, half-maximal effective concentration: 1.18 nM
Estimate against measurement, compound 3: 1.2-fold (0.07 log units) below; low and high end bracket the measured number.
By their numbers in this assay, from the lowest: compound 2; then compound 3; then compound 1.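

In this assay, the outer ring of the aromatic group is sensitive to a single atom: replacing one ring carbon with nitrogen, which turns phenyl into pyridin-3-yl, gives a 3.5-fold higher number from compound 2 to compound 3 (0.54 log units; beyond the scatter). That step is modest and beyond the scatter, so the outer ring's composition does matter, but the change costs far less than the gap between compound 1 and compound 2. Most of that gain survives, with a 28-fold lower number from compound 1 to compound 3 (1.45 log units; beyond the scatter), so the advantage of this aromatic group over 4-(trifluoromethoxy)phenyl does not depend on an all-carbon outer ring, although no measurement here explains why the nitrogen raises the number.

The compounds shown leave open how far the outer ring tolerates other changes, for example whether a fluorine atom, a methoxy group or an amine on it would bring the number back towards that of compound 2 or raise it further. They also cannot tell whether this modest step would be the same with a different chain in place of the hydroxybutyl carbamate end of the shared core.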